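Replacing an aryl acyl group with nitrooxymethyl carbonyl

This account rests on a few compounds, and the source may have more. Where it says the series, first, only, none or still open, it means among the compounds named here.

Three compounds sharing one core have been followed in an ADME assay on a cell-free system (plasma, Homo sapiens) for metabolic stability, with Plasma (Rattus norvegicus) as the target, read by HPLC, at pH 7.4; a higher number here means that the compound lasts longer, a lower number that the compound disappears faster. Compound 1 `CC(=O)Oc1ccccc1C(=O)O[C@H]1CO[C@H]2[C@@H]1OC[C@H]2OC(=O)c1ccc(C)cc1` gives 0.105 h. Compound 2 `CC(=O)Oc1ccccc1C(=O)O[C@H]1CO[C@H]2[C@@H]1OC[C@H]2OC(=O)c1ccccc1OC(=O)c1ccccc1` gives 0.385 h, and compound 3 `CC(=O)Oc1ccccc1C(=O)O[C@H]1CO[C@H]2[C@@H]1OC[C@H]2OC(=O)c1ccc([N+](=O)[O-])cc1` gives 0.0462 h. Among these three numbers compound 1 stands second highest: its nearest neighbour is compound 3, and the step of a 2.3-fold lower number from compound 1 to compound 3 (0.36 log units; beyond the scatter) is the only single-point change measured so far. Compound 2 lies furthest from compound 1, with the higher number of the set.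

Compound 4 `CC(=O)Oc1ccccc1C(=O)O[C@H]1CO[C@H]2[C@@H]1OC[C@H]2OC(=O)CO[N+](=O)[O-]` is not yet measured. It differs from compound 1 in one place: (nitrooxy)methyl in place of 4-methylphenyl on a carbonyl carbon.

Among the compounds with values here, only one measured step speaks to this change. The step of a 2.3-fold lower number from compound 1 to compound 3 (0.36 log units; beyond the scatter) shows that putting a nitro group where a methyl stood, on the aromatic carbon, lowered the half-life by a modest amount. The change to compound 4 goes further, removing the 4-methylphenyl altogether and setting (nitrooxy)methyl on the carbonyl carbon. Within the data shown here, no measured compound carries such a group, so the size of the step is uncertain, but it is expected to run downward, beyond the scatter, as in compound 3 with 0.0462 h. The half-life of compound 4 in this assay is therefore estimated at 0.04 h, within a range of 0.012 h to 0.12 h, an expected step of a 2.6-fold lower number from compound 1 to compound 4 (0.42 log units; beyond the scatter).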

Compound 4, half-life: 0.06 h
Compound 4: the middle estimate sits 1.5-fold (0.18 log units) below what was measured; the range from low to high includes it.
By their numbers in this assay, from the lowest: compounds 3, 4 and 1 (each within the scatter of the next, the first and the last beyond it); then compound 2.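

In this assay, within the data shown here, the step of a 1.8-fold lower number from compound 1 to compound 4 (0.24 log units; within the scatter) gives the first reading of what happens when the ring of the 4-methylphenyl group is removed altogether from this carbonyl carbon: a (nitrooxy)methyl group, which has no ring, stands in its place and the result stays within the scatter of compound 1. The step of a 1.3-fold higher number from compound 3 to compound 4 (0.11 log units; within the scatter) also lies within the scatter, so although the step of a 2.3-fold lower number from compound 1 to compound 3 (0.36 log units; beyond the scatter) separates compound 1 and compound 3 beyond the scatter, compound 4 cannot be told apart from either of them, and an aromatic ring on this carbonyl carbon is not needed for a reading in this range. Nothing available explains these readings or gives a cause for them.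

The compounds shown leave open whether a plain methyl on this carbonyl carbon would read like (nitrooxy)methyl, so the part played by the nitrooxy group itself remains unknown. They also leave open how a longer chain carrying the nitrooxy group, or an amine or a carboxylic acid on that chain, would read in this assay.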